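This account rests on a few compounds, and the source may have more. Where it says the series, first, only, none or still open, it means among the compounds named here.

Within the data shown here, in a functional assay on HCT-116 cells (Homo sapiens) for inhibition, read by CCK-8 assay, with a stated time of 48 h (a lower number here means a stronger inhibitor, a higher number a weaker inhibitor), compound 2 `COc1cc(-c2ccnc3cc(-c4cn(C)c5ccccc45)nn23)cc(OC)c1OC` gives 762 nM, the only actual number so far. Compound 1 `COc1cc(-c2ccnc3cc(-c4cccc(C#N)c4)nn23)cc(OC)c1OC` is reported only as a limit, > 10000 nM. Compound 3 `COc1cc(-c2ccnc3cc(-c4cccc(C)c4)nn23)cc(OC)c1OC` differs from compound 2 by 3-methylphenyl in place of 1-methyl-1H-indol-3-yl on an aromatic carbon, which puts 3-methylphenyl where compound 1 carries 3-cyanophenyl. Among the measured compounds shown here, the single step bearing on this change is large and beyond the scatter, an at least 13-fold lower number from compound 1 to compound 2 (1.11 log units; beyond the scatter), so losing the 1-methyl-1H-indol-3-yl is expected to give a higher number. The estimated step is a 6.6-fold higher number from compound 2 to compound 3 (0.82 log units; beyond the scatter). Compound 3 is expected at 5000 nM, within a range of 1500 nM to 15000 nM.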

Compound 3, half-maximal inhibitory concentration: 6150 nM
Beside the measured number, compound 3's estimate is 1.2-fold (0.09 log units) below it, within the range that was stated.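

Replacing 1-methyl-1H-indol-3-yl with 3-methylphenyl in this assay gives an 8.1-fold higher number from compound 2 to compound 3 (0.91 log units; beyond the scatter), so the cost of leaving the indole at this aromatic carbon now has a measured size, not just a floor. Methyl in place of cyano gives an at least 1.6-fold lower number from compound 1 to compound 3 (0.21 log units; that floor lies within the scatter), which leaves 3-methylphenyl and 3-cyanophenyl unordered. Compound 1 is reported only as a limit: the limit of > 10000 nM in this assay, at which 1 of the 3 values shown sits.

On these data alone, what 1H-indol-3-yl without its methyl, or a 3-methoxyphenyl or 3-aminophenyl on this carbon, would give remains open.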